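The compounds below may be only part of what the source reports. "The series", "measured", "known", "first", "only" and "open" are said of these compounds alone.

Measured so far in a functional assay on MCF7 cells (Homo sapiens) for antiproliferative activity, read by MTT assay, with a stated time of 48 h; a higher number here means a weaker inhibitor, a lower number a stronger inhibitor:
- compound 1 `COc1ccc(C2=NN(c3nc(-c4ccc(C(F)(F)F)cc4)cs3)C(c3cccs3)C2)cc1`: 45700 nM
- compound 2 `Fc1ccc(C2=NN(c3nc(-c4ccc(C(F)(F)F)cc4)cs3)C(c3cccs3)C2)cc1`: 1330 nM
- compound 3 `FC(F)(F)c1ccc(-c2csc(N3N=C(c4ccc(Br)cc4)CC3c3cccs3)n2)cc1`: 7810 nM

Compound 3 stands second highest of the three numbers in this assay. Its nearest neighbour is compound 1, and the step of a 5.9-fold lower number from compound 1 to compound 3 (0.77 log units; beyond the scatter) is beyond the scatter; the step of a 5.9-fold higher number from compound 2 to compound 3 (0.77 log units; beyond the scatter) puts compound 2 further off, on the lower side, also beyond the scatter. The largest single step in the set is a 34-fold lower number from compound 1 to compound 2 (1.54 log units; beyond the scatter).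

Compound 4 `FC(F)(F)c1ccc(-c2csc(N3N=C(c4ccc(Cl)cc4)CC3c3cccs3)n2)cc1` differs from compound 3 in one place: chloro in place of bromo on an aromatic carbon, on an aromatic carbon of a six-membered aromatic ring of carbon only, para to a large group.

Within the data shown here, only one measured step exchanges one halogen for another on that carbon, a 5.9-fold higher number from compound 2 to compound 3 (0.77 log units; beyond the scatter), and it is modest. Among the measured compounds shown here, no measured step shows chloro at this position, so the expectation rests on chloro sitting between fluoro and bromo in the set as a whole. In this assay a small step toward a lower number is expected, a 2.0-fold lower number from compound 3 to compound 4 (0.29 log units; within the scatter), which may not clear the scatter. Compound 4 is estimated at 4000 nM, with a range from 1300 nM to 12000 nM.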

Compound 4, half-maximal inhibitory concentration: 160 nM
Estimate against measurement, compound 4: 25-fold (1.40 log units) above; measured number outside the range, below it.
By their numbers in this assay, from the lowest: compound 4; then compound 2; then compound 3; then compound 1.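

Working notes on the halogen series: in this assay, the change from 4-bromophenyl to 4-chlorophenyl (a 49-fold lower number from compound 3 to compound 4 (1.69 log units; beyond the scatter)) is far larger than the only halogen exchange previously available at this carbon (a 5.9-fold higher number from compound 2 to compound 3 (0.77 log units; beyond the scatter)), so a single halogen exchange here can shift the number strongly. Chloro also outdoes fluoro (an 8.3-fold lower number from compound 2 to compound 4 (0.92 log units; beyond the scatter)) and methoxy (a 290-fold lower number from compound 1 to compound 4 (2.46 log units; beyond the scatter)), which makes compound 4 the strongest of the four, and the halogens do not run in periodic-table order: the number is lowest with chloro, higher with fluoro and higher again with bromo. Nothing available bears on why the order falls this way.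

Still open, as far as these compounds go, is whether this sharp preference is specific to chloro, since an iodo, methyl, nitrile or amine group on the same carbon would show whether the low number belongs to chloro alone or extends to other substituents. Also open, from the compounds shown here alone, is whether the chloro advantage survives when the trifluoromethyl group elsewhere in the shared core is exchanged for another chloro or a methyl group.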